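Swapping the Ring on the Thiocarbonyl Carbon of Compound 1

A few compounds are considered here, and "the series" means these few. Any claim that something is new, unique, unknown or untested is made for them only; others in the source may bear on it.

Compound 1 `Cc1ccnc(/C(N)=N/NC(=S)N2CCSCC2)c1` gives 74.2% in a functional assay on MCF7 cells (Homo sapiens) for cytotoxicity, read by MTT assay, with a stated time of 72 h, tested at 30 uM (on this read-out higher numbers stand for more inhibition of growth at the one concentration tested and lower numbers for less inhibition of growth), the highest of the three numbers measured. Among the measured compounds shown here, compound 2 `N/C(=N\NC(=S)N1CCSCC1)c1ccccn1` gives 72.6%, and the only single-site step, a number 1.6 percentage points lower from compound 1 to compound 2 (within the scatter), stays within the scatter. Compound 3 `N/C(=N\NC(=S)N1CCOCC1)c1ccc(F)cn1` gives 56.7%, a lower number beyond the scatter, but it differs from compound 1 in more than one place. Compound 4 `Cc1ccnc(/C(N)=N/NC(=S)N2CCCCC2)c1` differs from compound 1 by piperidin-1-yl in place of thiomorpholin-4-yl on a thiocarbonyl carbon. No measured step changes the ring on the thiocarbonyl carbon, so nothing shown bears directly on this change. Compound 4 is therefore expected to stay near the starting number, the expected step being a number 6.2 percentage points lower from compound 1 to compound 4 (within the scatter), not clearly beyond the scatter. The estimate for compound 4 is 68%, expected between 50% and 84%.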

Compound 4, percent growth inhibition at one concentration: 61.7%
For compound 4 the middle estimate is 6.3 percentage points above the measured one, within the range that was stated.
By their numbers in this assay, from the lowest: compounds 3 and 4 (each within the scatter of the next); then compounds 2 and 1 (each within the scatter of the next).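

In this assay the change to piperidin-1-yl from thiomorpholin-4-yl on the thiocarbonyl carbon gives a number 12.5 percentage points lower from compound 1 to compound 4 (beyond the scatter) and so this position, unlike the aromatic carbon of the earlier methyl-to-hydrogen step, shows a single-site change that clears the scatter. Nothing available explains this drop.

As far as these compounds go, how the number responds to piperazin-1-yl or an open-chain dimethylamino group at this position on the core of compound 1 remains open. So does whether the step would hold on the core of compound 2, without the methyl.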